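The source may hold more compounds than are shown below. What is called first, only, known or untested is meant among the compounds shown, and "the series" means these compounds.

Measured so far in a functional assay on B16 cells (Mus musculus) for inhibition; a lower number here means a stronger inhibitor, a higher number a weaker inhibitor:
compound 1 `COc1cc(/C=C/C(=O)c2cccc(NC(=O)c3ccc(Cl)c(Cl)c3)c2)ccc1O`: 3.88 ug/mL
compound 2 `COc1cc(/C=C/C(=O)c2cccc(NC(=O)c3ccccc3)c2)ccc1O`: 0.82 ug/mL

Among the compounds with values here, compound 2 holds the lowest of the two numbers in this assay; the only measured step, a 4.7-fold lower number from compound 1 to compound 2 (0.68 log units; beyond the scatter), exchanged one aryl group for another on the amide carbonyl carbon. Compound 3 `COC(=O)C(=O)Nc1cccc(C(=O)/C=C/c2ccc(O)c(OC)c2)c1` differs from compound 2 by methoxycarbonyl in place of phenyl on a carbonyl carbon. Within the data shown here, no measured step removes the aromatic ring at this position, so the bearing of the measured step is indirect. A weaker result is expected for compound 3, at 2 ug/mL (range 0.6 ug/mL to 7 ug/mL), a step of a 2.4-fold higher number from compound 2 to compound 3 (0.39 log units; beyond the scatter).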

Compound 3, half-maximal inhibitory concentration: 4.41 ug/mL
For compound 3 the middle estimate is 2.2-fold (0.34 log units) below the measured one; low and high end bracket the measured number.
By their numbers in this assay, from the lowest: compound 2; then compounds 1 and 3 (each within the scatter of the next).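

In this assay the change of phenyl to methoxycarbonyl on this carbonyl carbon gave a 5.4-fold higher number from compound 2 to compound 3 (0.73 log units; beyond the scatter) and so cost about as much as the 3,4-dichlorophenyl group did. Methoxycarbonyl and 3,4-dichlorophenyl are not told apart, with a 1.1-fold higher number from compound 1 to compound 3 (0.06 log units; within the scatter) between them, so only the unsubstituted phenyl stands out among the three groups at this place. Nothing measured here explains these numbers. From the compounds shown here alone, whether a single chlorine on the phenyl, an amine or a longer chain would match compound 2 stays open.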